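A few compounds are considered here, and "the series" means these few. Any claim that something is new, unique, unknown or untested is made for them only; others in the source may bear on it.

Working notes on the series.

Three compounds have numbers in a functional assay on HCC 2998 cells (Homo sapiens) for inhibition; a lower number here means a stronger inhibitor of growth, a higher number a weaker inhibitor of growth. Compound 1 `COc1cc(/C=C/C(=O)c2cccc(-n3cc(-c4ccc(Cl)cc4)[nH]c3=O)c2)cc(OC)c1OC` gives 2460 nM. Compound 2 `COc1cc(/C=C/C(=O)c2cccc(-n3cc(-c4ccccc4)[nH]c3=O)c2)ccc1O` gives 1510 nM. Compound 3 `COc1ccc(-c2cn(-c3cccc(C(=O)/C=C/c4cc(OC)c(OC)c(OC)c4)c3)c(=O)[nH]2)cc1` gives 1640 nM. Compound 2 holds the lowest of the three numbers, but its nearest neighbour compound 3 and its furthest neighbour compound 1 both sit within the scatter of it, so no order among the three can be claimed.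

The next compound, compound 4 `COc1cc(/C=C/C(=O)c2cccc(-n3cc(-c4ccc(Cl)cc4)[nH]c3=O)c2)ccc1O`, carries the change chloro in place of hydrogen on an aromatic carbon relative to compound 2. Among the measured compounds shown here, no measured step puts chloro in place of hydrogen at that carbon. For the measured compounds named here, the only step at the same carbon is a 1.5-fold lower number from compound 1 to compound 3 (0.18 log units; within the scatter), which swaps chloro for methoxy and stays within the scatter. Compound 1 and compound 2 differ in two places, so their values alone are compared and show only a gap within the scatter. The expectation is therefore a step of about a 1.2-fold higher number from compound 2 to compound 4 (0.08 log units; within the scatter) in this assay, with no direction beyond the scatter, and compound 4 is estimated at 1800 nM, likely between 900 nM and 3600 nM.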

Compound 4, concentration for 50% growth inhibition: 1850 nM
Compound 4: middle estimate off by 1.0-fold (0.01 log units), on the low side; low and high end bracket the measured number.
By their numbers in this assay, from the lowest: compounds 2, 3, 4 and 1 (each within the scatter of the next).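

In this assay, among the compounds shown here, phenyl to 4-chlorophenyl gives a 1.2-fold higher number from compound 2 to compound 4 (0.09 log units; within the scatter), the first direct reading of chloro in place of hydrogen on this aromatic carbon, para to a large group. The step lies within the scatter, so adding the chlorine shifts the number by no measurable amount in this pair, whereas the earlier step at this carbon, a 1.5-fold lower number from compound 1 to compound 3 (0.18 log units; within the scatter), compared chloro only with methoxy. No supporting evidence bears on this result.

The compounds shown leave open whether a different kind of group at this carbon, such as an amine or a carboxylic acid, would move the number beyond the scatter. They also leave open whether chloro on another carbon of this ring would read the same way.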